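Changing the aromatic group on a carbonyl carbon

The compounds below may be only part of what the source reports. "The series", "measured", "known", "first", "only" and "open" are said of these compounds alone.

Compound 1 `CC(/C=C/C1=CCCCC1(C)C)=C\C=C\C(C)=C\COC(=O)c1cc(O)c(O)c(O)c1` gives 35000 nM
Compound 2 `CC(/C=C/C1=CCCCC1(C)C)=C\C=C\C(C)=C\COC(=O)c1c(O)cccc1O` gives 14000 nM
Compound 3 `COc1ccc(O)c(C(=O)OC/C=C(C)/C=C/C=C(C)/C=C/C2=CCCCC2(C)C)c1` gives 570000 nM

In a toxicity assay on cells (Fibroblast, Homo sapiens) for cytotoxicity (on this read-out lower numbers stand for stronger inhibition and higher numbers for weaker inhibition), compound 1 stands in the middle of these three numbers, with compound 2 lower and compound 3 higher. Compound 4 `COc1cccc(O)c1C(=O)OC/C=C(C)/C=C/C=C(C)/C=C/C1=CCCCC1(C)C` has not yet been measured. It keeps the core of compound 1 and changes one group: 2-hydroxy-6-methoxyphenyl in place of 3,4,5-trihydroxyphenyl on a carbonyl carbon. Here, 2-hydroxy-6-methoxyphenyl sits in place of 3,4,5-trihydroxyphenyl on a carbonyl carbon.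

Three measured steps change this same group: a modest one (a 2.5-fold lower number from compound 1 to compound 2 (0.40 log units; beyond the scatter)) and two large ones (a 16-fold higher number from compound 1 to compound 3 (1.21 log units; beyond the scatter) and a 41-fold higher number from compound 2 to compound 3 (1.61 log units; beyond the scatter)). For the measured compounds named here, the only measured compound with a methoxy group, compound 3, has the highest number (570000 nM). Compound 2, with 2,6-dihydroxyphenyl, has the lowest (14000 nM). The new group shares features of both, so a value between these two is expected, which would mean a modest rise from compound 1 and weaker inhibition in this assay. The estimate is a 2.6-fold higher number from compound 1 to compound 4 (0.41 log units; beyond the scatter) as the expected step. Compound 4 is expected at 90000 nM (range 20000 nM to 400000 nM).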

Compound 4, half-maximal inhibitory concentration: 230000 nM
The estimate for compound 4 lay 2.6-fold (0.41 log units) below the measured number; measured number inside the range.
By their numbers in this assay, from the lowest: compound 2; then compound 1; then compound 4; then compound 3.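

In this assay, for the compounds shown here, methyl in place of hydrogen on an oxygen on an aromatic ring gives a 16-fold higher number from compound 2 to compound 4 (1.22 log units; beyond the scatter) and so weaker inhibition, the first step in which that single change stands alone. The two methoxy compounds also differ from each other: 2-hydroxy-6-methoxyphenyl in place of 2-hydroxy-5-methoxyphenyl gives a 2.5-fold lower number from compound 3 to compound 4 (0.39 log units; beyond the scatter) and shows that the arrangement of the same two groups on the ring matters too, though this step is modest rather than large. With a 6.6-fold higher number from compound 1 to compound 4 (0.82 log units; beyond the scatter) as well, both methoxy compounds now have higher numbers than compound 1 and compound 2, and none of the four compounds goes against this pattern.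

From the compounds shown here alone, whether an ethoxy group, an amine or a carboxylic acid on this ring would keep the number low remains open. Nothing measured here explains why the methyl raises the number.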